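A few compounds are considered here, and "the series" means these few. Any claim that something is new, unique, unknown or untested is made for them only; others in the source may bear on it.

Measured compounds:
- compound 1, `C=CCn1c(=O)/c(=C\c2ccccc2Cl)[nH]c(=O)/c1=C\c1ccccc1OC`: in a functional assay on Huh-7 cells (Homo sapiens) for cytotoxicity, read by CCK-8 assay, with a stated time of 72 h (on this read-out higher numbers stand for weaker inhibition and lower numbers for stronger inhibition), compound 1 gives 6400 nM
- compound 2, `C=CCn1c(=O)/c(=C\c2cc(Br)ccc2F)[nH]c(=O)/c1=C\c1ccccc1OC`: in this assay compound 2 gives "not active" (no number reported)
- compound 3, `C=CCn1c(=O)/c(=C\c2cccc(C)c2)[nH]c(=O)/c1=C\c1ccccc1OC`: in this assay compound 3 gives 21400 nM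

Compound 3 carries the highest of the two numbers in this assay; its nearest neighbour is compound 1, and the step of a 3.3-fold higher number from compound 1 to compound 3 (0.52 log units; beyond the scatter) lies beyond the scatter, while compound 2 is recorded without a number. Compound 4, `C=CCn1c(=O)/c(=C\c2ccccc2F)[nH]c(=O)/c1=C\c1ccccc1OC`, has not yet been measured in this assay. It differs from compound 3 in one place: 2-fluorophenyl in place of 3-methylphenyl on a double-bonded chain carbon bound to an aromatic carbon.

Going by the values given here, the only measured step that bears on this change is a 3.3-fold higher number from compound 1 to compound 3 (0.52 log units; beyond the scatter), in which a 2-chlorophenyl gave way to the 3-methylphenyl of compound 3 and the number rose modestly. Compound 4 reverses the direction of that step, bringing back a halogen-bearing ring on the same chain carbon, so a modest step back towards the number of compound 1 is expected, though compound 2, which also carries a 2-fluorophenyl, returned no number. The step from compound 3 to compound 4 is therefore estimated at a 2.4-fold lower number from compound 3 to compound 4 (0.38 log units; beyond the scatter). For compound 4 the expected value in this assay is 9000 nM, with a range from 3000 nM to 30000 nM.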

Compound 4, half-maximal inhibitory concentration: 31300 nM
Estimate against measurement, compound 4: 3.5-fold (0.54 log units) below, and the stated range ends below it.
By their numbers in this assay, from the lowest: compound 1; then compounds 3 and 4 (each within the scatter of the next).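

In this assay, 2-fluorophenyl and 3-methylphenyl on this double-bonded chain carbon cannot be told apart, with a 1.5-fold higher number from compound 3 to compound 4 (0.17 log units; within the scatter), so a halogen on the ring does not by itself set compound 4 apart from compound 3. The exchange of fluoro for chloro on an aromatic carbon does count, with a 4.9-fold higher number from compound 1 to compound 4 (0.69 log units; beyond the scatter), which shows that in this pair the identity of the halogen matters and that, of the compounds with numbers, only compound 1 stands apart. No measurement given here accounts for this difference between the two halogens.

Steps to compound 2 cannot be read, as it has no number. From the compounds shown here alone, whether a nitrile, an amine or a carboxylic acid on this ring would come closer to compound 1 remains open.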